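Fixing the ring stereocentre of compound 3

This account rests on a few compounds, and the source may have more. Where it says the series, first, only, none or still open, it means among the compounds named here.

In a physicochemical assay for solubility, read by chemiluminescence, measured as kinetic solubility (a higher number here means a more soluble compound, a lower number a less soluble compound), compound 1 (`O=C(C1CCCN1)N1CCC2(CCN(c3nccc(NCc4ccc(Cl)cc4Cl)n3)CC2)C1`) gives 79 ug/mL, compound 2 (`O=C([C@H]1CCCN1)N1CCC2(CCN(c3nccc(NCc4ccc(Cl)cc4Cl)n3)CC2)C1`) gives 180 ug/mL and compound 3 (`Clc1ccc(CNc2ccnc(N3CCC4(CCN(CC5CCCN5)C4)CC3)n2)c(Cl)c1`) gives 270 ug/mL. For the standing of compound 3, a 3.4-fold higher number from compound 1 to compound 3 (0.53 log units; beyond the scatter) lies beyond the scatter, whereas a 1.5-fold higher number from compound 2 to compound 3 (0.18 log units; within the scatter) lies within it.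

Compound 4 (`Clc1ccc(CNc2ccnc(N3CCC4(CCN(C[C@@H]5CCCN5)C4)CC3)n2)c(Cl)c1`) carries one change: the two compounds have the same atoms and bonds; at least one stereo element is drawn with a configuration in one of them and without one in the other: 1 of 1 stereo elements differ; a stereocentre at a saturated ring carbon is drawn without a configuration in compound 3 and S in compound 4. The stereocentre at a saturated ring carbon is drawn without a configuration in compound 3 and S in compound 4.

One measured step is of the same kind: a 2.3-fold higher number from compound 1 to compound 2 (0.36 log units; beyond the scatter), a modest one, where the only difference is the fact that one of compounds 1 and 2 is drawn with a defined configuration and the other without, at the place where they differ. That step comes from the (pyrrolidin-2-yl)carbonyl compounds and ends in R, whereas this one sits in a (pyrrolidin-2-yl)methyl compound and ends in S, so it carries over only weakly. A small upward move is therefore expected, probably not clearing the scatter. The expected step is a 1.1-fold higher number from compound 3 to compound 4 (0.06 log units; within the scatter). For compound 4 the estimated value is 310 ug/mL, with an expected range of 160 ug/mL to 580 ug/mL.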

Compound 4, solubility: 56 ug/mL
Estimate against measurement, compound 4: 5.5-fold (0.74 log units) above; the whole stated range lies above it.
By their numbers in this assay, from the lowest: compounds 4 and 1 (each within the scatter of the next); then compounds 2 and 3 (each within the scatter of the next).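

In this assay, a 4.8-fold lower number from compound 3 to compound 4 (0.68 log units; beyond the scatter) runs opposite to a 2.3-fold higher number from compound 1 to compound 2 (0.36 log units; beyond the scatter), so a defined configuration at this ring carbon does not raise the number in every case: compound 2 (R) follows that direction and compound 4 (S) goes against it. The advantage of compound 3 over compound 1 does not carry over to the S form, since a 1.4-fold lower number from compound 1 to compound 4 (0.15 log units; within the scatter), while a 3.2-fold lower number from compound 2 to compound 4 (0.51 log units; beyond the scatter). The step to compound 4 leaves atoms and bonds untouched, so the whole drop rests on one difference: the fact that one of compounds 3 and 4 is drawn with a defined configuration and the other without, at the place where they differ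

Open, going by these compounds, is how the R configuration behaves in the (pyrrolidin-2-yl)methyl compounds and the S configuration in the (pyrrolidin-2-yl)carbonyl compounds, so the effects of configuration and of the carbonyl or methyl link cannot yet be separated. Also open, on these data alone, is what a longer chain in place of the methyl link, or a carboxylic acid on the (pyrrolidin-2-yl)methyl group, would do to this number.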